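This account rests on a few compounds, and the source may have more. Where it says the series, first, only, none or still open, it means among the compounds named here.

The numbers come from a functional assay on the whole organism (strain Hartley) for inhibition, with Cavia porcellus as the target, with stated times of 15 min and 2 min; a higher number here means that more compound is needed for the effect, a lower number that less compound is needed.

Compound 1, `CCCCC1([C@H](O)/C=C/C2CCC(=O)[C@@H]2CCCCCC(=O)O)CCC1`, gives 0.032 mg/kg.
Compound 2, `CCCCC1([C@H](O)/C=C/C2CCC(=O)[C@@H]2CCCCCCCCC(=O)OCC)CCC1`, gives 4.38 mg/kg.
Compound 3, `CCCCC1([C@H](O)/C=C/C2CCC(=O)[C@@H]2CCCCSCC(=O)OCC)CCC1`, gives 0.3 mg/kg.

Compound 3 stands second highest of the three numbers: a 9.4-fold higher number from compound 1 to compound 3 (0.97 log units; beyond the scatter), while a 15-fold lower number from compound 2 to compound 3 (1.16 log units; beyond the scatter). Compound 4, `CCCCC1([C@H](O)/C=C/C2CCC(=O)[C@@H]2CCCCSCC(=O)O)CCC1`, differs from compound 3 in one place: hydrogen in place of ethyl on an oxygen next to a carbonyl group. Among the compounds with values here, two measured steps bear on this. a 140-fold higher number from compound 1 to compound 2 (2.14 log units; beyond the scatter), where the ethyl ester entered together with a longer chain. a 9.4-fold higher number from compound 1 to compound 3 (0.97 log units; beyond the scatter), where the ethyl ester entered together with the sulfur link. In both, the compound carrying the ethyl ester gave the higher number, and compound 1, which carries carboxy, gave the lowest number of the three. Compound 4 carries carboxy while keeping the sulfur link of compound 3. Within the data shown here, no measured pair shows the ethyl removed on its own, so the size is uncertain. The step expected is a lower number for compound 4: a 6.0-fold lower number from compound 3 to compound 4 (0.78 log units; beyond the scatter), roughly the size of a 9.4-fold higher number from compound 1 to compound 3 (0.97 log units; beyond the scatter) reversed in direction. The estimate for compound 4 in this assay is 0.05 mg/kg, with a range from 0.015 mg/kg to 0.2 mg/kg.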

Compound 4, dose for half-maximal effect: 0.171 mg/kg
Compound 4: middle estimate off by 3.4-fold (0.53 log units), on the low side, and the stated range covers the measured number.
By their numbers in this assay, from the lowest: compound 1; then compounds 4 and 3 (each within the scatter of the next); then compound 2.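

In this assay, taking off the ethyl alone gives a 1.8-fold lower number from compound 3 to compound 4 (0.24 log units; within the scatter) and so lies within the scatter, which means that with the sulfur link in the chain, the ethyl ester and the free carboxy cannot be told apart. With carboxy on both compounds, the change of chain alone still gives a 5.3-fold higher number from compound 1 to compound 4 (0.73 log units; beyond the scatter) in the same assay, so the gap between compound 1 and the sulfur-linked compounds does not need the ester to appear. The largest new step, a 26-fold lower number from compound 2 to compound 4 (1.41 log units; beyond the scatter) here, swaps the chain and the ester together, so it cannot be assigned to either change alone.

Open, on these data alone, is whether a methyl ester or an amide in place of the ethyl ester, or an oxygen in place of the sulfur, would behave the same way. Nothing available gives a reason for any of these steps.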